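Fluoro to chloro on the benzyl ring: compound 4

This account rests on a few compounds, and the source may have more. Where it says the series, first, only, none or still open, it means among the compounds named here.

Compound 1 `Cc1cc(Nc2nc(NCc3ccccc3F)nc3[nH]ncc23)n[nH]1` gives 389 nM in an assay on isolated protein for inhibition of serine/threonine-protein kinase PAK 4 (Homo sapiens), read by HTRF, with a stated time of 60 min; a lower number here means a stronger inhibitor, a higher number a weaker inhibitor. Compound 2 `Cc1cc(Nc2nc(NCc3ccccc3Cl)nc3[nH]ncc23)n[nH]1` gives 668 nM in this assay; it differs from compound 1 by chloro in place of fluoro on an aromatic carbon, and the step is a 1.7-fold higher number from compound 1 to compound 2 (0.23 log units; within the scatter). Compound 3 `Cc1cc(Nc2nc(NCc3ccc(F)cc3)nc3[nH]ncc23)n[nH]1` gives 395 nM in this assay; its core differs from the core of compound 1 by 4-fluorophenyl in place of 2-fluorophenyl on a saturated chain carbon bound to a nitrogen on an aromatic ring, with the step of a 1.0-fold higher number from compound 1 to compound 3 (0.01 log units; within the scatter). Compound 4 `Cc1cc(Nc2nc(NCc3ccc(Cl)cc3)nc3[nH]ncc23)n[nH]1` is not yet measured in this assay. It differs from compound 3 by chloro in place of fluoro on an aromatic carbon. This is the same kind of change as that between compound 1 and compound 2, but the place is not identical: there the chloro sits ortho to a large group, here para to a large group. The step from compound 3 to compound 4 is expected to be a 1.5-fold higher number from compound 3 to compound 4 (0.18 log units; within the scatter), resting on the measured step of a 1.7-fold higher number from compound 1 to compound 2 (0.23 log units; within the scatter). Compound 4 is estimated at 600 nM, expected to lie between 300 nM and 1200 nM.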

Compound 4, half-maximal inhibitory concentration: 515 nM
Compound 4: the middle estimate sits 1.2-fold (0.07 log units) above what was measured; the range from low to high includes it.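

In this assay, chloro in place of fluoro carries from one core to the other with no detectable difference between the two steps: the same change on two cores in this assay, a 1.7-fold higher number (0.23 log units; within the scatter) from compound 1 to compound 2 and a 1.3-fold higher number (0.12 log units; within the scatter) from compound 3 to compound 4, 1.3-fold (0.12 log units) apart, within the scatter of two such steps. The step on the newer core is a 1.3-fold higher number from compound 3 to compound 4 (0.12 log units; within the scatter), and the other two new steps are a 1.3-fold lower number from compound 2 to compound 4 (0.11 log units; within the scatter) and a 1.3-fold higher number from compound 1 to compound 4 (0.12 log units; within the scatter), so no listed step among compounds 1 to 4 lies beyond the scatter. This shows agreement for one halogen exchange on two cores; it does not show that chloro changes the number on either core, or that the agreement extends to other cores.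

Still open, going by these compounds, is whether a methoxy group, a nitrile or an amine on the benzyl ring would give a step beyond the scatter. The same question stands for a carboxylic acid or a longer chain in place of the benzyl group.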